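Changing the aryl group on the aromatic nitrogen

The compounds below may be only part of what the source reports. "The series", "measured", "known", "first", "only" and "open" are said of these compounds alone.

Measured compounds:
- compound 1 `Fc1ccc(Nc2cc(Nc3ccc(Oc4ccncc4-c4cccnc4)c(F)c3)ncn2)cc1F`: 7630 nM
- compound 2 `Cn1c(=O)c(C(=O)Nc2ccc(Oc3ccncc3-c3cccnc3)c(F)c2)nn(-c2ccccc2F)c1=O`: 610 nM

Of the compounds shown here, two have been measured in a functional assay on A549 cells (Homo sapiens) for cytotoxicity, read by MTT assay, with a stated time of 72 h; on this read-out lower numbers stand for stronger inhibition and higher numbers for weaker inhibition. Compound 1 gives 7630 nM, while compound 2 gives 610 nM. Compound 2 therefore holds the lowest number of the two, and its nearest neighbour, compound 1, sits a long way higher, well beyond the scatter. Within the data shown here, no pair differing in one place has been measured, so no single-change step is known.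

Compound 3 `Cn1c(=O)c(C(=O)Nc2ccc(Oc3ccncc3-c3cccnc3)c(F)c2)nn(-c2ccc(Cl)cc2)c1=O` has not yet been measured. It differs from compound 2 only in one place: 4-chlorophenyl in place of 2-fluorophenyl on an aromatic nitrogen, a change of 4-chlorophenyl in place of 2-fluorophenyl on an aromatic nitrogen. The rest of the molecule, including the amide and the aryl ether that compound 2 shares with compound 1, is unchanged.

Among the measured compounds shown here, with no measured step of this kind, the writer expects compound 3 to stay close to compound 2, with a change of a 1.1-fold higher number from compound 2 to compound 3 (0.06 log units; within the scatter) that is not expected to exceed the scatter in either direction. Compound 3 is estimated at 700 nM, within a range of 250 nM to 2000 nM.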

Compound 3, half-maximal inhibitory concentration: 930 nM
Estimate against measurement, compound 3: 1.3-fold (0.12 log units) below; the range from low to high includes it.
By their numbers in this assay, from the lowest: compounds 2 and 3 (each within the scatter of the next); then compound 1.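

In this assay, among these compounds, the one measured change on the aromatic nitrogen, 4-chlorophenyl in place of 2-fluorophenyl, gives a 1.5-fold higher number from compound 2 to compound 3 (0.18 log units; within the scatter). Among the compounds shown here, this is the first single-change step, and it shows that, on this core, these two halogenated phenyl groups cannot be told apart by this read-out, even though the halogen and its place on the phenyl ring differ between them. Nothing available bears on why the two compounds read alike.

The step changes the halogen and its place on the phenyl ring together, so the compounds shown cannot say whether either alteration alone would leave the number within the scatter, or whether two separate effects happen to offset each other. They also leave open how far this tolerance reaches beyond halogenated phenyl groups, for example whether an unsubstituted phenyl, a benzyl, a cyclohexyl or a pyridyl group on the same nitrogen would stay as close to compound 2 or would move the number beyond the scatter in either direction.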